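Three tolerated compounds and a fourth awaiting measurement

The source may report more compounds than this note shows. Statements on the series, on what has been measured and on what is new or still open speak of the compounds shown alone.

Compound 1, `COc1ccc([C@H]2CC(=O)N(Cc3cccc([N+](=O)[O-])c3)C2)cc1OC1CCCC1`: in a functional assay on HEK293 cells (Homo sapiens) for cytotoxicity (a higher number here means that more compound is tolerated, a lower number that less compound is tolerated), compound 1 gives > 10000 nM, which is a limit of the assay and not a number.
Compound 2, `COc1ccc([C@H]2CC(=O)N(c3ccccc3)C2)cc1OC1CCCC1`: in this assay compound 2 gives > 10000 nM, again a limit.
Compound 3, `COc1ccc([C@H]2CC(=O)N(c3cccc(O)c3)C2)cc1OC1CCCC1`: in this assay compound 3 gives > 10000 nM, also a limit.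

Compound 3 therefore stands where every measured compound in this set stands, at the limit, as the limit of > 10000 nM in this assay, at which 3 of the 3 values shown sit, makes plain. The three steps among the measured compounds, a step that the two limits leave unreadable from compound 1 to compound 2, a step that the two limits leave unreadable from compound 1 to compound 3 and a step that the two limits leave unreadable from compound 2 to compound 3, are all unreadable for that reason: when both ends sit at a limit, the size of the step cannot be taken from the numbers.

Compound 4, `COc1ccc([C@H]2CC(=O)N(c3ccc(N)cc3)C2)cc1OC1CCCC1`, is the next compound. Its change from compound 3 is 4-aminophenyl in place of 3-hydroxyphenyl on an amide-type nitrogen in a ring. For the measured compounds named here, no measured step gives a readable size for a change of this kind, so the only guidance is that every compound so far has been tolerated up to the limit. The expectation is therefore that compound 4 will behave in the same way, with a step of a number no higher from compound 3 to compound 4 (the limit leaves the size open) that is expected to be none beyond the scatter. Compound 4 is estimated at 10000 nM, within 5000 nM to 30000 nM, most likely reported once more as a limit.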

Compound 4, half-maximal cytotoxic concentration: > 10000 nM
Compound 4: no number, only a limit; the forecaster's own chance of this, stated with the estimate: 85%; the middle value lies on the limit itself.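

In this assay compound 4 gives > 10000 nM, which is a limit and not a number. The steps linking compound 4 to compound 1, compound 2 and compound 3 cannot be read, because both ends of each sit at a limit: the limit of > 10000 nM in this assay, at which 4 of the 4 values shown sit.

The compounds shown leave open how much of each compound the cells would actually tolerate, and whether the group on the amide-type nitrogen changes that amount.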